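Amide heteroaryl exchange: fluoromethyl oxazole to methoxypyrazine

The source may report more compounds than this note shows. Statements on the series, on what has been measured and on what is new or still open speak of the compounds shown alone.

Measured compounds:
compound 1, `C[C@@]1(c2cc(NC(=O)c3ncc(OCF)nc3N)ccc2F)C=C(CF)OC(N)=N1`, 3.1
compound 2, `C[C@@]1(c2cc(NC(=O)c3coc(CF)n3)ccc2F)C=C(CF)OC(N)=N1`, 2.2
compound 3, `CC1=COC(N)=N[C@]1(C)c1cc(NC(=O)c2ccc(C#N)cn2)ccc1F`, 1.5

In a physicochemical assay for lipophilicity, read by HPLC, in phosphate buffer, measured as octanol-water partition, with a stated time of 1 h, at pH 7.4 (a higher number here means a more lipophilic compound, a lower number a more polar compound), compound 2 stands second highest of the three numbers. Its nearest neighbour is compound 3, which gives 1.5, lower beyond the scatter; the furthest is compound 1, reached by the step of a number 0.90 log units lower from compound 1 to compound 2 (beyond the scatter), which replaced one heteroaryl group on the carbonyl carbon by another and lowered the number by a modest amount.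

Compound 4, `COc1cnc(C(=O)Nc2ccc(F)c([C@]3(C)C=C(CF)OC(N)=N3)c2)cn1`, is not yet measured. It differs from compound 2 in one place: 5-methoxypyrazin-2-yl in place of 2-(fluoromethyl)-1,3-oxazol-4-yl on a carbonyl carbon. Among the measured compounds shown here, the only measured step at this position is a number 0.90 log units lower from compound 1 to compound 2 (beyond the scatter), where a six-membered two-nitrogen ring gave way to a five-membered ring and the number fell. Compound 3 differs from compound 2 in two places and offers no single-point comparison, so only its value is noted. On the strength of the step between compound 1 and compound 2, an increase beyond the scatter is expected for compound 4, a number 0.40 log units higher from compound 2 to compound 4 (beyond the scatter), though a smaller one than the full reversal, since the entering ring lacks the amino and fluoromethoxy groups of compound 1. For compound 4 the estimated value in this assay is 2.6, within a range from 2 to 3.2.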

Compound 4, distribution coefficient: 2.7
For compound 4 the middle estimate is 0.10 log units below the measured one, within the range that was stated.
By their numbers in this assay, from the lowest: compound 3; then compound 2; then compound 4; then compound 1.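

With 5-methoxypyrazin-2-yl on the carbonyl carbon, this assay gives a number 0.50 log units higher from compound 2 to compound 4 (beyond the scatter), so a pyrazinyl group without the amino and fluoromethoxy groups still reads above the 2-(fluoromethyl)-1,3-oxazol-4-yl group. The same change also gives a number 0.40 log units lower from compound 1 to compound 4 (beyond the scatter), which divides the earlier difference into two parts, each beyond the scatter: one between the two pyrazinyl groups and one between 5-methoxypyrazin-2-yl and the oxazolyl group. Nothing available here accounts for either step.

The compounds shown do not separate the amino group from the change of fluoromethoxy to methoxy, as compound 1 and compound 4 differ in both at once. Also open, on these data alone, is how a dimethylamino group or a carboxylic acid in place of the methoxy group would read in this assay.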